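A few compounds are considered here, and "the series" means these few. Any claim that something is new, unique, unknown or untested is made for them only; others in the source may bear on it.

Three compounds have been measured in a functional assay on ECa-109 cells (Homo sapiens) for inhibition, read by MTT assay, with a stated time of 72 h; on this read-out lower numbers stand for stronger inhibition and higher numbers for weaker inhibition:

compound 1, `CC(C)c1ccc(-c2nc(SCc3cn(CC(=O)NC(=O)Nc4ccccn4)nn3)nc(Nc3cccc(Cl)c3)c2C#N)cc1`, which gives 13300 nM;
compound 2, `CC(C)c1ccc(-c2nc(SCc3cn(CC(=O)NC(=O)Nc4ccccn4)nn3)nc(Nc3cccc(C(F)(F)F)c3)c2C#N)cc1`, which gives 24200 nM;
compound 3, `COc1ccc(Nc2nc(SCc3cn(CC(=O)NC(=O)Nc4ccccn4)nn3)nc(-c3ccc(C(C)C)cc3)c2C#N)cc1`, which gives 5420 nM.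

Compound 3 has the lowest number of the three. Its distance from compound 1 is a 2.5-fold lower number from compound 1 to compound 3 (0.39 log units; beyond the scatter), and from compound 2 it is a 4.5-fold lower number from compound 2 to compound 3 (0.65 log units; beyond the scatter), both beyond the scatter, whereas the gap between compound 1 and compound 2 is a 1.8-fold higher number from compound 1 to compound 2 (0.26 log units; within the scatter), within the scatter. All three share the same core and differ only in the group carried on one ring nitrogen.

Compound 4, `Cc1ccccc1Nc1nc(SCc2cn(CC(=O)NC(=O)Nc3ccccn3)nn2)nc(-c2ccc(C(C)C)cc2)c1C#N`, is the next member of this series. The change from compound 3 is 2-methylphenyl in place of 4-methoxyphenyl on a nitrogen on an aromatic ring. The two steps that touch the same nitrogen are the ones that bear on it: both replaced a substituted phenyl with 4-methoxyphenyl and lowered the number. Within the data shown here, removing 4-methoxyphenyl again, now in favour of 2-methylphenyl, is therefore expected to move the number back up by a modest amount, though no measured step matches this exact exchange, so a step within the scatter cannot be ruled out. The expected step is a 1.8-fold higher number from compound 3 to compound 4 (0.24 log units; within the scatter). Compound 4 is thus estimated at about 9500 nM in this assay , with a plausible range from 3500 nM to 26000 nM.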

Compound 4, half-maximal inhibitory concentration: 7230 nM
For compound 4 the middle estimate is 1.3-fold (0.12 log units) above the measured one; the range from low to high includes it.
By their numbers in this assay, from the lowest: compounds 3, 4, 1 and 2 (each within the scatter of the next, the first and the last beyond it).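

On this nitrogen on an aromatic ring, the exchange gives a 1.3-fold higher number from compound 3 to compound 4 (0.13 log units; within the scatter), so a group with no hydrogen-bond acceptor, 2-methylphenyl, cannot be told apart from 4-methoxyphenyl here. The same group gives a 3.3-fold lower number from compound 2 to compound 4 (0.52 log units; beyond the scatter), making it the second group shown to stand clear of 3-(trifluoromethyl)phenyl, yet a 1.8-fold lower number from compound 1 to compound 4 (0.26 log units; within the scatter) does not separate it from 3-chlorophenyl. No measurement shown here explains these differences.

The compounds shown leave open how an unsubstituted phenyl would compare in this assay, and whether a phenyl carrying an amine or a carboxylic acid would move the number beyond the scatter. With a different substituent at each ring position, they also leave open whether moving any one group around the ring matters, such as 2-methylphenyl compared with 4-methylphenyl.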